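The source may hold more compounds than are shown below. What is called first, only, known or untested is meant among the compounds shown, and "the series" means these compounds.

Measured so far in a physicochemical assay for lipophilicity, read by HPLC, at pH 7.4; on this read-out lower numbers stand for lower lipophilicity and higher numbers for higher lipophilicity

Compound 1 (`C[C@@H](Oc1cc2cnn(CCC(=O)O)c2cc1Cl)c1ccccn1`) reads 1.7
Compound 2 (`C[C@@H](Oc1cc2ccn(CCC(=O)O)c2cc1Cl)c1ccccn1`) reads 2.17
Compound 3 (`O=C(O)CCn1c(=O)oc2cc(Cl)c(Cl)cc21`) reads 1.61

Compound 3 sits at 1.61 at the low end of this small set. Compound 1 lies within the scatter of it, while compound 2 stands higher, beyond the scatter.

Compound 4 (`O=C(O)CCn1c(=O)oc2cc(OCC3CC3)c(Cl)cc21`) has cyclopropylmethoxy in place of chloro on an aromatic carbon. For the measured compounds named here, no measured pair here shows this kind of change, so the expectation is tentative. More heavy atoms enter than leave, and a small rise in this assay is expected, of a size near the scatter. The estimated change is a number 0.34 log units higher from compound 3 to compound 4 (beyond the scatter) and it could still prove too small to tell apart from repeat measurements. For compound 4 the estimate is 1.95 with an expected range from 1.55 to 2.4 on this scale.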

Compound 4, distribution coefficient: 2.09
Beside the measured number, compound 4's estimate is 0.14 log units below it; low and high end bracket the measured number.
By their numbers in this assay, from the lowest: compounds 3 and 1 (each within the scatter of the next); then compounds 4 and 2 (each within the scatter of the next).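

In this assay, for the compounds shown here, cyclopropylmethoxy in place of chloro gives the first step in this set between compounds that differ in one place, a number 0.48 log units higher from compound 3 to compound 4 (beyond the scatter), a modest change. So this aromatic carbon, ortho to the remaining chloro group, is a place where exchanging one group for another moves the read-out by more than the scatter. Nothing available explains why the number moves.

Still open, from the compounds shown here alone, is which part of the new group goes with the step: the oxygen, the three-membered ring or the added carbons. A methoxy or ethoxy group on this same carbon could start to separate them.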